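The source may report more compounds than this note shows. Statements on the series, on what has been measured and on what is new or still open speak of the compounds shown alone.

Compound 1 `CC(C(=O)NCc1ccc(C(F)(F)F)cc1N1CCCCCC1)c1ccc(NS(C)(=O)=O)c(F)c1` gives the lowest number of the three measured compounds in an assay on CHO cells for antagonist activity at transient receptor potential cation channel subfamily V member 1 (Homo sapiens), read by FLIPR (on this read-out lower numbers stand for stronger inhibition and higher numbers for weaker inhibition), at 1.6 nM. Compound 2 `CC(C(=O)NCc1ccc(C(F)(F)F)cc1N1CCCCCCC1)c1ccc(NS(C)(=O)=O)c(F)c1` gives 2.8 nM in this assay, and compound 3 `CC(C(=O)NCc1ccc(C(F)(F)F)cc1N1CCN(C2CCCCC2)CC1)c1ccc(NS(C)(=O)=O)c(F)c1` gives 13.8 nM. The change from compound 1 to compound 4 `CC(C(=O)NCc1ccc(C(F)(F)F)cc1SCc1ccco1)c1ccc(NS(C)(=O)=O)c(F)c1` is ((furan-2-yl)methyl)sulfanyl in place of azepan-1-yl on an aromatic carbon. Among the measured steps, a 1.8-fold higher number from compound 1 to compound 2 (0.24 log units; within the scatter) and an 8.6-fold higher number from compound 1 to compound 3 (0.94 log units; beyond the scatter) both replace the same group on the same aromatic carbon; the closest analogy is the exchange of azepan-1-yl for a group of different shape, which gave an 8.6-fold higher number from compound 1 to compound 3 (0.94 log units; beyond the scatter). A modest loss is therefore expected, a 3.8-fold higher number from compound 1 to compound 4 (0.57 log units; beyond the scatter), and compound 4 is estimated at 6 nM in this assay, within a range of 1.5 nM to 25 nM.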

Compound 4, inhibition constant: 3.2 nM
Estimate against measurement, compound 4: 1.9-fold (0.27 log units) above; low and high end bracket the measured number.
By their numbers in this assay, from the lowest: compounds 1, 2 and 4 (each within the scatter of the next); then compound 3.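

In this assay, this aromatic carbon accepts ((furan-2-yl)methyl)sulfanyl in place of a nitrogen-linked ring without a step beyond the scatter, with a 2.0-fold higher number from compound 1 to compound 4 (0.30 log units; within the scatter) and a 1.1-fold higher number from compound 2 to compound 4 (0.06 log units; within the scatter) as the two comparisons. The nitrogen link shared by compounds 1, 2 and 3 is therefore not needed for a low number here, and the piperazine stands apart, with a 4.3-fold lower number from compound 3 to compound 4 (0.63 log units; beyond the scatter) as its gap. No measurement shown here accounts for these steps. On these data alone, whether the sulfur or the furan ring carries the result stays open. A benzylsulfanyl or a ((furan-2-yl)methyl)oxy group would separate the two.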